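This account rests on a few compounds, and the source may have more. Where it says the series, first, only, none or still open, it means among the compounds named here.

`COc1ccc(/C=C/c2ccc3ccccc3c2)cc1` compound 1, > 5000 nM
`FC(F)(F)c1ccc(/C=C/c2ccc3ccccc3c2)cc1` compound 2, > 5000 nM

In a functional assay on HT-29 cells (Homo sapiens) for inhibition (on this read-out higher numbers stand for weaker inhibition and lower numbers for stronger inhibition), compound 1 gives > 5000 nM, which is a limit of the assay rather than a number. Compound 2 gives > 5000 nM, also a limit. The step that the two limits leave unreadable from compound 1 to compound 2 therefore cannot be read; the limit of > 5000 nM in this assay, at which 2 of the 2 values shown sit, is all that the two values show. Compound 3, `COc1ccc(/C=C/c2ccc3ccccc3c2)cc1N`, differs from compound 1 by amino in place of hydrogen on an aromatic carbon. Among the compounds with values here, no measured step bears on this change, and compound 1 itself stands only at a limit. For compound 3 a value near that limit is expected, 5000 nM, within 1500 nM to 20000 nM. The step of a number no higher from compound 1 to compound 3 (the limit leaves the size open) is thus expected to stay within the scatter.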

Compound 3, half-maximal inhibitory concentration: > 5000 nM
Compound 3: no number, only a limit; the forecaster's own chance of this, stated with the estimate: 70%; the middle value lies on the limit itself.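

Within the data shown here, compound 3 gives > 5000 nM, a limit and not a number, so no step from compound 1 to compound 3 can be read. The compounds shown leave open how strongly any of them acts in this assay, and whether trifluoromethyl or amino changes that.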